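The source may hold more compounds than are shown below. What is called first, only, known or untested is meant among the compounds shown, and "the series" means these compounds.

Measured in a functional assay on LNCaP cells (Homo sapiens) for antiproliferative activity, read by propidium iodide staining, with a stated time of 96 h; a higher number here means a weaker inhibitor, a lower number a stronger inhibitor:
- compound 1 `CC(O)(COc1cccc(S(F)(F)(F)(F)F)c1)C(=O)Nc1ccc(S(F)(F)(F)(F)F)cc1` gives 12000 nM
- compound 2 `CC(O)(COc1cccc(C(F)(F)F)c1)C(=O)Nc1ccc(S(F)(F)(F)(F)F)cc1` gives 24700 nM

Of these two compounds, compound 2 has the higher number in this assay, and compound 1 is its nearest neighbour. The next compound, compound 3 `CC(O)(COc1cc(C(F)(F)F)cc(C(F)(F)F)c1)C(=O)Nc1ccc(S(F)(F)(F)(F)F)cc1`, differs from compound 2 by trifluoromethyl in place of hydrogen on an aromatic carbon, which is trifluoromethyl in place of hydrogen on an aromatic carbon. For the measured compounds named here, only one measured step bears on this, and only indirectly, since it is an exchange of groups and not an addition. That step, a 2.1-fold higher number from compound 1 to compound 2 (0.31 log units; beyond the scatter), was modest and lay just beyond the scatter. It shows a higher number with the smaller group, so a similarly modest move towards a lower number is expected in this assay, though it may stay within the scatter. The expected change is a 1.6-fold lower number from compound 2 to compound 3 (0.22 log units; within the scatter). Compound 3 is estimated at 15000 nM, with an expected range from 6000 nM to 40000 nM.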

Compound 3, half-maximal inhibitory concentration: 2300 nM
Compound 3: middle estimate off by 6.5-fold (0.81 log units), on the high side, outside the stated range (below it).
By their numbers in this assay, from the lowest: compound 3; then compound 1; then compound 2.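

Replacing hydrogen with trifluoromethyl on this aromatic carbon, meta to a trifluoromethyl group, gave in this assay a large gain: an 11-fold lower number from compound 2 to compound 3 (1.03 log units; beyond the scatter). For the compounds shown here, the only earlier step, a 2.1-fold higher number from compound 1 to compound 2 (0.31 log units; beyond the scatter), was a modest exchange of one group for another at a single ring position, so it did not show that filling a carbon that had carried only hydrogen could move the number this far. This position is therefore far from indifferent in this series, although nothing shown accounts for the size of the step.

On these data alone, whether a chlorine atom, a methyl group or a nitrile on the same carbon would give a step of similar size remains open. A single step also cannot show whether the gain depends on the trifluoromethyl group already on the ring.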